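Thiocarbonyl amine variation in a benzamide series

A few compounds are considered here, and "the series" means these few. Any claim that something is new, unique, unknown or untested is made for them only; others in the source may bear on it.

Measured so far:
compound 1, `CN(Cc1cccnc1)C(=S)SCc1ccc(C(=O)Nc2ccccc2N)cc1`, 45.9%
compound 2, `Nc1ccccc1NC(=O)c1ccc(CSC(=S)N2CCCC2)cc1`, 27%
compound 3, `CN1CCN(C(=S)SCc2ccc(C(=O)Nc3ccccc3N)cc2)CC1`, 29.6%

All three share one core and differ only in the amine attached to the thiocarbonyl carbon. In a functional assay on MGC-803 cells (Homo sapiens) for antiproliferative activity, read by CCK-8 assay, with a stated time of 72 h, tested at 2 uM (on this read-out higher numbers stand for a stronger effect at the one concentration tested and lower numbers for a weaker effect), compound 3 stands second highest of the three numbers. Its nearest neighbour is compound 2, and the step of a number 2.6 percentage points higher from compound 2 to compound 3 (within the scatter) lies within the scatter, so the two cannot be ordered. Its furthest is compound 1, and the step of a number 16.3 percentage points lower from compound 1 to compound 3 (beyond the scatter) lies beyond the scatter; the parallel step a number 18.9 percentage points lower from compound 1 to compound 2 (beyond the scatter) shows the same.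

Compound 4, `Nc1ccccc1NC(=O)c1ccc(CSC(=S)N2CCc3ccccc32)cc1`, is not yet measured. It differs from compound 3 in one place: 2,3-dihydro-1H-indol-1-yl in place of 4-methylpiperazin-1-yl on a thiocarbonyl carbon.

For the measured compounds named here, no measured step bears directly on this change. Going by the values given here, the only cyclic-amine comparison available, a number 2.6 percentage points higher from compound 2 to compound 3 (within the scatter), was within the scatter, so swapping one ring amine for another gave no measurable step; the one step beyond the scatter, a number 16.3 percentage points lower from compound 1 to compound 3 (beyond the scatter), concerned a non-cyclic amine and does not transfer. Among the compounds with values here, the 2,3-dihydro-1H-indol-1-yl group has no counterpart among the measured compounds. For compound 4 the step of a number 6.4 percentage points higher from compound 3 to compound 4 (within the scatter) is therefore expected to be small, with wide uncertainty. In this assay compound 4 is estimated at 36%, within a range from 18% to 58%.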

Compound 4, a percentage reported as inhibition, at one concentration (the size of the read-out at that concentration, not a potency): 44%
Beside the measured number, compound 4's estimate is 8 percentage points below it; the range from low to high includes it.
By their numbers in this assay, from the lowest: compounds 2 and 3 (each within the scatter of the next); then compounds 4 and 1 (each within the scatter of the next).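

In this assay, the amine on the thiocarbonyl carbon can separate two ring amines, which the earlier cyclic pair could not: 2,3-dihydro-1H-indol-1-yl in place of 4-methylpiperazin-1-yl gives a number 14.4 percentage points higher from compound 3 to compound 4 (beyond the scatter), and in place of pyrrolidin-1-yl it gives a number 17 percentage points higher from compound 2 to compound 4 (beyond the scatter). A cyclic amine also matches the non-cyclic methyl((pyridin-3-yl)methyl)amino group, with a number 1.9 percentage points lower from compound 1 to compound 4 (within the scatter), so among these four compounds the split no longer runs between cyclic and non-cyclic amines but between compounds 1 and 4, whose amines carry an aromatic ring, and compounds 2 and 3, whose amines do not. Nothing among the data shown explains these steps.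

From the compounds shown here alone, whether the aromatic ring itself drives this split remains open, since compounds 1 and 4 differ in much else, and a benzylmethylamino or a 4-phenylpiperazin-1-yl group on the same carbon would bear on that question. Also open, going by these compounds, is whether the order at this single concentration would carry over to full concentration-response potency.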